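This account rests on a few compounds, and the source may have more. Where it says the series, first, only, none or still open, it means among the compounds named here.

Three compounds share one core, and in an assay on isolated protein for inhibition of Amine oxidase [flavin-containing] B (Homo sapiens), read by fluorescence (on this read-out higher numbers stand for weaker inhibition and lower numbers for stronger inhibition), compound 1 `COc1cccc(-c2csc(N/N=C/c3ccco3)n2)c1` gives 6780 nM, while compound 3 `CCCCC/C(C)=N/Nc1nc(-c2cccc(OC)c2)cs1` gives 6720 nM. Compound 2 `COc1cccc(-c2csc(N/N=C3\CCC(C)C3)n2)c1` stands lowest of the three in this assay with 231 nM, beyond the scatter from each of the others, so on these numbers it is the strongest inhibitor of the set. Among the compounds with values here, the one step that isolates a single change is a 29-fold lower number from compound 1 to compound 2 (1.47 log units; beyond the scatter), where the five-membered aromatic ring with 1 hetero atom made way for the five-membered non-aromatic ring of carbon only.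

Compound 4 `COc1cccc(-c2csc(N/N=C/c3cccs3)n2)c1` reverses that direction: a group of 7 heavy atoms (5 carbon, 1 nitrogen, 1 sulfur; one five-membered aromatic ring with 1 hetero atom) in place of a group of 7 heavy atoms (6 carbon, 1 nitrogen; one five-membered non-aromatic ring of carbon only), on a nitrogen on an aromatic ring. Within the data shown here, the group that enters is, by these counts, close to the one that left in compound 1, differing in sulfur for oxygen. The step from compound 1 to compound 2 therefore bears directly on this change, and a rise of similar size is expected in this assay, as a 22-fold higher number from compound 2 to compound 4 (1.34 log units; beyond the scatter). Compound 4 is thus expected to give about 5000 nM, between 1500 nM and 15000 nM.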

Compound 4, half-maximal inhibitory concentration: 494 nM
Compound 4: middle estimate off by 10-fold (1.01 log units), on the high side; measured number outside the range, below it.
By their numbers in this assay, from the lowest: compound 2; then compound 4; then compounds 3 and 1 (each within the scatter of the next).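

At this place, on a nitrogen on an aromatic ring, the two five-membered aromatic rings do not behave alike: in this assay, thiophen-2-yl in place of furan-2-yl gives a 14-fold lower number from compound 1 to compound 4 (1.14 log units; beyond the scatter) on the same core. The high number of compound 1 therefore does not hold for every five-membered aromatic ring, and the gap to the non-aromatic ring of carbon only shrinks to a 2.1-fold higher number from compound 2 to compound 4 (0.33 log units; beyond the scatter) and stays beyond the scatter. No measurement at hand gives a reason for the difference between the two aromatic rings.

From the compounds shown here alone, whether a phenyl or pyridine ring in this place would track thiophen-2-yl or furan-2-yl stays open. So does whether the ring of compound 2 depends on its methyl group, since no compound without that methyl is shown.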